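Paw edema series: piperazinyl amide replaces hexyl chain

A few compounds are considered here, and "the series" means these few. Any claim that something is new, unique, unknown or untested is made for them only; others in the source may bear on it.

The shared core of compound 1 `CNC(=O)CC1CCc2cc(OC)c(OC)cc21` carries an amide whose nitrogen bears only a methyl group; in a functional assay on the whole organism (strain Wistar) for inhibition, with Rattus norvegicus as the target, read by paw edema, with stated times of 60 min and 6 h, at a dose of 100 mg/kg by the oral route (a higher number here means more inhibition at the dose given (going by the name of the read-out), a lower number less inhibition), compound 1 gives 24.1%. Compound 2 `CCCCCNC(=O)CC1CCc2cc(OC)c(OC)cc21` lengthens the chain on that nitrogen, and in this assay compound 2 gives 35.2%. Compound 3 `CCCCCCNC(=O)CC1CCc2cc(OC)c(OC)cc21` lengthens it further, and in this assay compound 3 gives 38.3%. The steps are a number 11.1 percentage points higher from compound 1 to compound 2 (beyond the scatter) and a number 14.2 percentage points higher from compound 1 to compound 3 (beyond the scatter), both beyond the scatter, whereas a number 3.1 percentage points higher from compound 2 to compound 3 (within the scatter) stays within it. Compound 3 therefore holds the highest number of the three, but is separated from compound 2 only within the scatter and from compound 1 beyond it.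

Compound 4 `COc1cc2c(cc1OC)C(CC(=O)N1CCNCC1)CC2` changes the amide substituent altogether: piperazin-1-yl in place of hexylamino on a carbonyl carbon. For the measured compounds named here, no measured step removes the chain in favour of a ring, so the bearing of the three steps is indirect: they show only that a longer chain on the amide nitrogen gives a modest gain over hydrogen, and that the hexyl chain is now lost. The expected step is a number 8.3 percentage points lower from compound 3 to compound 4 (within the scatter), a small downward move that is expected to lie within the usual scatter. Compound 4 is estimated at 30%, with a range from 15% to 45%.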

Compound 4, a percentage reported as inhibition, in the whole organism at one dose (the size of the read-out at that dose, not a potency): 33.3%
Beside the measured number, compound 4's estimate is 3.3 percentage points below it; the range from low to high includes it.
By their numbers in this assay, from the lowest: compounds 1, 4, 2 and 3 (each within the scatter of the next, the first and the last beyond it).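

In this assay a ring can stand on the carbonyl carbon in place of an open chain: a number 5 percentage points lower from compound 3 to compound 4 (within the scatter) and a number 1.9 percentage points lower from compound 2 to compound 4 (within the scatter) are both read as no separation, so neither hexylamino nor pentylamino is needed there for a number of this size. The comparison with the smallest group is less clear-cut, as a number 9.2 percentage points higher from compound 1 to compound 4 (within the scatter) also stays within the scatter, whereas both chains stood beyond it from compound 1, which leaves compound 4 not separated from any of the other three compounds. Nothing at hand explains these steps or says what the ring contributes at this position.

Open, on these data alone, is whether the second ring nitrogen of piperazin-1-yl counts at all, a question that morpholin-4-yl or piperidin-1-yl on the same carbonyl carbon would address, as would a methyl or acetyl group on that nitrogen. Also open, as far as these compounds go, is how far the chain series runs past hexylamino, for instance to octylamino, and whether any such amide would separate from compound 3 by more than the scatter.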